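This account rests on a few compounds, and the source may have more. Where it says the series, first, only, none or still open, it means among the compounds named here.

Three compounds have been measured in a functional assay on LNCaP cells (Homo sapiens) for antiproliferative activity, read by propidium iodide staining, with a stated time of 96 h; a higher number here means a weaker inhibitor, a lower number a stronger inhibitor:

Compound 1, `CC(O)(CSc1ccc(S(F)(F)(F)(F)F)cc1)C(=O)Nc1cccc(S(F)(F)(F)(F)F)c1`, gives 12700 nM.
Compound 2, `CC(O)(CSc1ccc(OC(F)(F)F)cc1)C(=O)Nc1cccc(S(F)(F)(F)(F)F)c1`, gives 10300 nM.
Compound 3, `CC(O)(COc1ccc(S(F)(F)(F)(F)F)cc1)C(=O)Nc1ccc(S(F)(F)(F)(F)F)cc1`, gives 9800 nM.

All three numbers sit close together, and none of the gaps between them goes beyond the usual scatter of repeated measurements of this kind, so no order of strength can be read from them.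

Compound 1 and compound 2 share a core and differ in one place, (a group of 5 heavy atoms (1 carbon, 1 oxygen, 3 fluorine; no ring) in place of a group of 6 heavy atoms (5 fluorine, 1 sulfur; no ring), on an aromatic carbon). The step that this change made is a 1.2-fold lower number from compound 1 to compound 2 (0.09 log units; within the scatter). Compound 3 carries a different core; how it differs from compound 1 is not broken down here, as the two differ in more than one place.

Compound 4, `CC(O)(COc1ccc(OC(F)(F)F)cc1)C(=O)Nc1ccc(S(F)(F)(F)(F)F)cc1`, has not yet been measured. It stands to compound 3 as compound 2 stands to compound 1: the difference is a group of 5 heavy atoms (1 carbon, 1 oxygen, 3 fluorine; no ring) in place of a group of 6 heavy atoms (5 fluorine, 1 sulfur; no ring), on an aromatic carbon. The place of the change reads the same in both pairs, so this is the same change made on a second core.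

The step from compound 3 to compound 4 is estimated to be a 1.2-fold lower number from compound 3 to compound 4 (0.06 log units; within the scatter), about the size of the earlier one. Among the measured compounds shown here, this expectation rests on the single measured instance of the change, a 1.2-fold lower number from compound 1 to compound 2 (0.09 log units; within the scatter), which stayed within the scatter, and on no more than that. For compound 4 in this assay the estimate is 8500 nM, with a likely range from 4500 nM to 16000 nM.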

Compound 4, half-maximal inhibitory concentration: 18600 nM
Estimate against measurement, compound 4: 2.2-fold (0.34 log units) below; measured number outside the range, above it.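

In this assay, putting trifluoromethoxy in place of the group made of sulfur and fluorine, on the second core, gave a 1.9-fold higher number from compound 3 to compound 4 (0.28 log units; within the scatter). On paper this step and the earlier one point in opposite directions, but a newcomer should not read that as a reversal, since the gap between them is no larger than two such steps can show by chance: the same change on two cores in this assay, a 1.2-fold lower number (0.09 log units; within the scatter) from compound 1 to compound 2 and a 1.9-fold higher number (0.28 log units; within the scatter) from compound 3 to compound 4, 2.3-fold (0.37 log units) apart, within the scatter of two such steps What this shows is that nothing here separates the behaviour of the change on the two cores, while it does not show that the change carries over reliably, since each step on its own stays within the scatter, so neither core gives a clear effect to carry, and two pairs are too few to make a rule for the series.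

The compounds shown leave open whether a different group on that aromatic carbon, such as an amine, a nitrile or a carboxylic acid, would give a step that stands clear of the scatter. They also leave open what the same exchange would do on the ring attached to the amide nitrogen, since all four compounds keep the sulfur and fluorine group there.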